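From trifluoromethoxy to hydroxy on a shared core

The source may hold more compounds than are shown below. What is called first, only, known or untested is meant among the compounds shown, and "the series" means these compounds.

- Compound 1 `FC(F)(F)c1ccc(-c2ccc(-c3ccc(-c4nc5ccccc5[nH]4)cc3)cc2)cc1`: 100000 nM
- Compound 2 `FC(F)(F)Oc1ccc(-c2ccc(-c3ccc(-c4nc5ccccc5[nH]4)cc3)cc2)cc1`: 100000 nM
- Compound 3 `Oc1ccc(-c2ccc(-c3ccc(-c4nc5ccccc5[nH]4)cc3)cc2)cc1`: not yet measured

In a functional assay on A2780 cells (Homo sapiens) for inhibition, read by sulforhodamine B assay (a higher number here means a weaker inhibitor of growth, a lower number a stronger inhibitor of growth), compound 2 gives 100000 nM, level with compound 1. Compound 3 turns its trifluoromethoxy into hydroxy: hydrogen in place of trifluoromethyl on an oxygen on an aromatic ring. Here hydrogen takes the place of trifluoromethyl on an oxygen on an aromatic ring. Among the compounds with values here, the only measured step, no change at the digits printed from compound 1 to compound 2 (within the scatter), is a different swap and offers loose guidance. It showed no sensitivity to the group changed there. A modest move toward stronger inhibition is expected, estimated as a 3.3-fold lower number from compound 2 to compound 3 (0.52 log units; beyond the scatter), though no change remains possible. For compound 3 the expected value is 30000 nM, with an estimated range of 5000 nM to 100000 nM.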

Compound 3, concentration for 50% growth inhibition: 36000 nM
Estimate against measurement, compound 3: 1.2-fold (0.08 log units) below; low and high end bracket the measured number.
By their numbers in this assay, from the lowest: compound 3; then compounds 1 and 2 (each within the scatter of the next).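

In this assay, hydrogen in place of trifluoromethyl on the oxygen brings a 2.8-fold lower number from compound 2 to compound 3 (0.44 log units; beyond the scatter) and hydroxy in place of trifluoromethyl on the aromatic carbon brings a 2.8-fold lower number from compound 1 to compound 3 (0.44 log units; beyond the scatter) as well. So this position, which showed no response when one fluorinated group replaced the other, does respond once a hydroxy stands there, although the gain is modest.

On these data alone, whether an amine or a carboxylic acid at this position would move the number further stays open. Nothing measured here explains the shift seen with hydroxy.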